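Hydrazone aryl variation in a triazolylpyridine urea series

The compounds below may be only part of what the source reports. "The series", "measured", "known", "first", "only" and "open" are said of these compounds alone.

Measured so far:
- compound 1 `CN(C)CCn1cnnc1-c1cc(Oc2ccc(NC(=O)N/N=C/c3ccc(F)cc3)cc2F)ccn1`: 1370 nM
- compound 2 `CN(C)CCn1cnnc1-c1cc(Oc2ccc(NC(=O)N/N=C/c3c(O)ccc4ccccc34)cc2F)ccn1`: 670 nM

In a functional assay on HT-29 cells (Homo sapiens) for cytotoxicity, read by MTT assay, with a stated time of 72 h (a higher number here means a weaker inhibitor, a lower number a stronger inhibitor), compound 1 gives 1370 nM and compound 2 gives 670 nM. Among the measured compounds shown here, the single step in hand, a 2.0-fold lower number from compound 1 to compound 2 (0.31 log units; beyond the scatter), is modest but beyond the scatter, so compound 2 holds the lower of the two measured values.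

Compound 3 `CN(C)CCn1cnnc1-c1cc(Oc2ccc(NC(=O)N/N=C/c3ccc(F)cc3Cl)cc2F)ccn1` has not yet been measured in this assay. Relative to compound 2 the change is 2-chloro-4-fluorophenyl in place of 2-hydroxynaphthalen-1-yl on a carbon with a double bond to nitrogen. For the measured compounds named here, the only step that bears on this position is the one from compound 1 to compound 2, which shows that moving from a small halogenated phenyl to the larger hydroxynaphthyl gained a modest amount. Going by the values given here, compound 3 returns to a halogenated phenyl, so the expectation is that much of the gain seen in compound 2 is given back and the number lands nearer to compound 1; the added chlorine is an untested variation and no step shows its size, so the estimate is anchored mainly on compound 1. For compound 3 the expected step is a 1.6-fold higher number from compound 2 to compound 3 (0.22 log units; within the scatter), giving an estimated value of 1100 nM with a range of 500 nM to 2500 nM.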

Compound 3, half-maximal inhibitory concentration: 510 nM
Compound 3: the middle estimate sits 2.2-fold (0.33 log units) above what was measured; low and high end bracket the measured number.
By their numbers in this assay, from the lowest: compounds 3 and 2 (each within the scatter of the next); then compound 1.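

Adding chloro to the phenyl ring at this position gives a 2.7-fold lower number from compound 1 to compound 3 (0.43 log units; beyond the scatter) in this assay, so the gain here does not depend on replacing the phenyl with the larger 2-hydroxynaphthalen-1-yl group. With a 1.3-fold lower number from compound 2 to compound 3 (0.12 log units; within the scatter), the two groups cannot be told apart in this assay, which means that a value at this level does not require the second aromatic ring or the hydrogen-bond donor present in compound 2. No measurement here gives a reason for either step.

Compound 2 changes the second ring and the hydroxyl together, so their separate contributions remain unresolved, and a simple phenyl carrying only a hydroxyl group would be needed to separate them. On these data alone, the chloro result also rests on a single pair of compounds, so it remains open whether a bromo, methyl or methoxy group in its place would give a similar step, or whether an amine or a carboxylic acid on the ring would keep the value at this level.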